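The source may hold more compounds than are shown below. What is called first, only, known or untested is meant among the compounds shown, and "the series" means these compounds.

Compound 1 `Fc1cccc(-c2nc(Nc3ccccc3)c3cc(F)ccc3n2)c1`: 48300 nM
Compound 2 `Nc1ccc(Nc2nc(-c3cccc(F)c3)nc3ccc(F)cc23)cc1`: > 50000 nM

These two compounds were tested in a functional assay on HT29-AK cells (Homo sapiens) for cytotoxicity, read by MTT assay, with a stated time of 48 h; on this read-out lower numbers stand for stronger inhibition and higher numbers for weaker inhibition. Compound 1 gives 48300 nM. Going by these compounds, compound 2 gives > 50000 nM, which is a limit of the assay and not a number, so its exact place is unknown.

Compound 3 `Cc1cccc(Nc2nc(-c3cccc(F)c3)nc3ccc(F)cc23)c1` has not yet been measured. It differs from compound 2 as follows: 3-methylphenyl in place of 4-aminophenyl on a nitrogen on an aromatic ring. In words, this is 3-methylphenyl in place of 4-aminophenyl on a nitrogen on an aromatic ring.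

Within the data shown here, only one measured step bears on this change: an at least 1.0-fold higher number from compound 1 to compound 2 (0.01 log units; that floor lies within the scatter). That step stays within the scatter, and the limit hides its true size. Compound 3 lacks the amino group, as does compound 1 at 48300 nM, so weak inhibition is expected again in this assay.

No change beyond the scatter is expected, and the estimated step is an at least 1.2-fold lower number from compound 2 to compound 3 (0.09 log units; that floor lies within the scatter). The estimate for compound 3 is 40000 nM, with an expected range of 15000 nM to 70000 nM.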

Compound 3, half-maximal inhibitory concentration: > 50000 nM
Compound 3 gave a limit, no number; the forecaster's own chance of this, stated with the estimate: 45%; middle value at least 1.2-fold (0.09 log units) from the limit.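

In this assay compound 3 gives > 50000 nM, which is a limit of the assay and not a number. Adding a methyl group to the phenyl ring on the nitrogen of compound 1 gives an at least 1.0-fold higher number from compound 1 to compound 3 (0.01 log units; that floor lies within the scatter), so this second small change to that ring, like the amino group before it, shows no stronger inhibition. The step between compound 2 and compound 3 cannot be read, and 4-aminophenyl and 3-methylphenyl on this nitrogen end at the same ceiling: the limit of > 50000 nM in this assay, at which 2 of the 3 values shown sit.

Going by these compounds, how far past that limit compound 2 and compound 3 truly lie remains unknown. Also open, on these data alone, is what a carboxylic acid or a longer alkyl chain on the phenyl ring at this nitrogen would do in this assay.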